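Sulfonyl Aryl Swap in a Pyridine Carbohydrazide Series

The source may hold more compounds than are shown below. What is called first, only, known or untested is meant among the compounds shown, and "the series" means these compounds.

Compound 1 `CC(=O)Nc1ccc(S(=O)(=O)NNC(=O)c2cccnc2Nc2ccc(Cl)cc2)cc1` was tested in a functional assay on SK-OV-3 cells (Homo sapiens) for antiproliferative activity; on this read-out lower numbers stand for stronger inhibition of growth and higher numbers for weaker inhibition of growth. In this assay compound 1 gives > 100000 nM, which is a limit of the assay rather than a number. A second compound, compound 2 `O=C(NNS(=O)(=O)c1ccc(F)cc1)c1cccnc1Nc1ccc(Cl)cc1Cl`, was also tested. In this assay compound 2 gives > 100000 nM, again a limit of the assay and not a measured number. Both results therefore sit at the same point, described as the limit of > 100000 nM in this assay, at which 2 of the 2 values shown sit, so neither compound shows measurable growth inhibition at the concentrations tested.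

Compound 3 `O=C(NNS(=O)(=O)c1ccc(Cl)cc1Cl)c1cccnc1Nc1ccc(Cl)cc1` has not yet been measured in this assay. It differs from compound 1 in one place: 2,4-dichlorophenyl in place of 4-acetamidophenyl on a sulfonyl sulfur. Among the measured compounds shown here, no measured step between any two compounds is available to guide the size of this change. With both measured compounds at the limit, compound 3 is expected to give 100000 nM, with a range from 30000 nM to 300000 nM. The step from compound 1 to compound 3 is estimated as a number no higher from compound 1 to compound 3 (the limit leaves the size open), essentially none beyond the scatter, most likely with the result again reported only as a limit.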

Compound 3, concentration for total growth inhibition: 52500 nM
The estimate for compound 3 lay 1.9-fold (0.28 log units) above the measured number; low and high end bracket the measured number.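

Among the compounds shown here, compound 3 is the one compound here whose result in this assay is a number and not a limit: the limit of > 100000 nM in this assay, at which 2 of the 3 values shown sit. Placing 2,4-dichlorophenyl in place of 4-acetamidophenyl on a sulfonyl sulfur gives an at least 1.9-fold lower number from compound 1 to compound 3 (0.27 log units; that floor lies within the scatter), so this position can accept a change that brings the read-out into the measurable range, even though the smallest step the data allow does not clear the usual scatter. For compound 1, > 100000 nM is a limit, so the step has a floor but no known upper end, and its true size could be small or much larger.

The swap changes several things at once, as it removes the acetamido group and adds two chlorine atoms, so this single pair cannot show which of these matters or whether both chlorine atoms are needed. A plain phenyl, a 4-chlorophenyl or a 4-aminophenyl group on the same sulfonyl sulfur would help separate these contributions, and a carboxylic acid on that ring would test a quite different kind of substituent at this position.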